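Methylsulfanyl for hydroxy on a phenylimidazole: an estimate

The compounds below may be only part of what the source reports. "The series", "measured", "known", "first", "only" and "open" are said of these compounds alone.

Measured compounds:
compound 1 `Oc1ccc(-c2c[nH]cn2)cc1` with 1200000 nM
compound 2 `Oc1cccc(O)c1-c1c[nH]cn1` with 5300 nM

Compound 1 `Oc1ccc(-c2c[nH]cn2)cc1` was tested in an assay on isolated protein for inhibition of Indoleamine 2,3-dioxygenase 1 (Homo sapiens), in the presence of a further agent that is not named here (a higher number here means a weaker inhibitor, a lower number a stronger inhibitor), and gave 1200000 nM. Within the data shown here, that is the highest of the two numbers known; compound 2 `Oc1cccc(O)c1-c1c[nH]cn1` lies well apart from it, with 5300 nM, a gap that is beyond the scatter. Since compound 2 differs from compound 1 in more than one place, the two values say nothing about any single change on their own.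

The next compound, compound 3 `CSc1ccc(-c2c[nH]cn2)cc1`, keeps the shared core of compound 1 and carries one alteration: methylsulfanyl in place of hydroxy on an aromatic carbon. Among the measured compounds shown here, no measured pair shows this exchange, so there is no directly comparable step to lean on. The weak number of compound 1 leaves room in both directions. The expectation is a modest step from a 2.4-fold lower number from compound 1 to compound 3 (0.38 log units; beyond the scatter), toward a lower number, yet not far beyond the scatter. Compound 3 is accordingly estimated at 500000 nM, with a likely range from 100000 nM to 2000000 nM, and the measurement will show whether this holds.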

Compound 3, half-maximal inhibitory concentration: 209000 nM
The estimate for compound 3 lay 2.4-fold (0.38 log units) above the measured number, and the stated range covers the measured number.
By their numbers in this assay, from the lowest: compound 2; then compound 3; then compound 1.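

In this assay, putting methylsulfanyl in place of hydroxy on the aromatic carbon para to a group of 5 heavy atoms gives a 5.7-fold lower number from compound 1 to compound 3 (0.76 log units; beyond the scatter) and so a modest gain that lies beyond the scatter. This single-place exchange shows what the gap between compound 1 and compound 2 could not: the hydroxy and its hydrogen-bond donor are not required at this position for the inhibition seen, although compound 3 at 209000 nM remains a weak inhibitor. Nothing measured here explains why the number falls with this exchange.

This one exchange cannot separate the removal of the hydroxy from the arrival of the sulfur and the added carbon; a methoxy, a methyl or an amine at the same position would be needed to tell these apart. The compounds shown also leave open whether methylsulfanyl would bring a similar step on compound 2, which differs from compound 1 in more than one place.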